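The source may report more compounds than this note shows. Statements on the series, on what has been measured and on what is new or still open speak of the compounds shown alone.

Working notes on the series, in an assay on FRT cells for positive allosteric modulation of Cystic fibrosis transmembrane conductance regulator variant N1303K (Homo sapiens), in the presence of a further agent that is not named here; a lower number here means that less compound is needed, a higher number that more compound is needed for the effect.

Compound 1 `COc1ccc2[nH]c3c(c2c1)CCNC31CCN(Cc2cc(Cl)ccc2[N+](=O)[O-])CC1` gives 7100 nM. Among the three measured compounds it carries the lowest number, but its nearest neighbour compound 3 `COc1ccc2[nH]c3c(c2c1)CCNC31CCN(Cc2ccc(F)c(F)c2)CC1` gives 11000 nM, and compound 2 `COc1ccc2[nH]c3c(c2c1)CCNC31CCN(Cc2cc(F)cc(F)c2)CC1` gives 11100 nM, both within the scatter of compound 1, so no order among the three can be read from these numbers.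

The next step keeps the shared core of compound 1 and changes the group on the saturated chain carbon bound to the amine nitrogen in the ring, giving compound 4 `COc1ccc2[nH]c3c(c2c1)CCNC31CCN(Cc2cccnc2)CC1`. The change: pyridin-3-yl in place of 5-chloro-2-nitrophenyl on a saturated chain carbon bound to an amine nitrogen in a ring

The measured steps that bear on it are those that also replace the 5-chloro-2-nitrophenyl at the same place: a 1.6-fold higher number from compound 1 to compound 2 (0.19 log units; within the scatter) and a 1.5-fold higher number from compound 1 to compound 3 (0.19 log units; within the scatter). Both remained within the scatter, and between the two difluorophenyl compounds a 1.0-fold lower number from compound 2 to compound 3 (0.00 log units; within the scatter). Going by the values given here, no measured step has introduced a ring with a hetero atom at this place, so the pyridin-3-yl is not covered directly.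

Given that every replacement of the 5-chloro-2-nitrophenyl so far has stayed within the scatter, a step of about a 1.4-fold higher number from compound 1 to compound 4 (0.15 log units; within the scatter) is expected, with no change beyond the scatter. Compound 4 is estimated at 10000 nM, with a range of 4000 nM to 30000 nM.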

Compound 4, half-maximal effective concentration: 17000 nM
For compound 4 the middle estimate is 1.7-fold (0.23 log units) below the measured one; the measured number falls inside the stated range.
By their numbers in this assay, from the lowest: compounds 1, 3, 2 and 4 (each within the scatter of the next, the first and the last beyond it).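

In this assay, going by these compounds alone, pyridin-3-yl is the first replacement at this place, on a saturated chain carbon bound to an amine nitrogen in a ring, to go beyond the scatter, with a 2.4-fold higher number from compound 1 to compound 4 (0.38 log units; beyond the scatter) for this change. Against the two difluorophenyl groups, the same ring remains inside the scatter, with a 1.5-fold higher number from compound 3 to compound 4 (0.19 log units; within the scatter) and a 1.5-fold higher number from compound 2 to compound 4 (0.19 log units; within the scatter) as the two steps, so compound 4 is separated only from compound 1, and compounds 2 and 3 are separated from neither. Nothing available explains this step.

The compounds shown leave open whether the step from compound 1 follows the ring nitrogen of pyridin-3-yl or the departure of the chlorine and nitro group. A plain phenyl or a pyridin-4-yl at this place would help to tell these two readings apart.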